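The source may report more compounds than this note shows. Statements on the series, on what has been measured and on what is new or still open speak of the compounds shown alone.

Compound 1 `CC(C)c1sc(-c2ccccc2)c(-c2cccc(F)c2)c1/C=C/[C@@H](O)C[C@@H](O)CC(=O)O` gives 49 nM in an assay on microsomes for inhibition of 3-hydroxy-3-methylglutaryl-coenzyme A reductase (Rattus norvegicus); on this read-out lower numbers stand for stronger inhibition and higher numbers for weaker inhibition. Compound 2 `CC(C)c1sc(-c2ccccc2)c(-c2ccc(F)cc2)c1/C=C/[C@@H](O)C[C@@H](O)CC(=O)O` gives 4.4 nM in this assay. Among the measured compounds shown here, the only step measured so far is an 11-fold lower number from compound 1 to compound 2 (1.05 log units; beyond the scatter), a swap of 4-fluorophenyl for 3-fluorophenyl on the shared core. Of the two compounds measured, compound 2 gives the lowest number. Compound 3 `COc1ccc(-c2c(-c3ccccc3)sc(C(C)C)c2/C=C/[C@@H](O)C[C@@H](O)CC(=O)O)cc1` differs from compound 2 by methoxy in place of fluoro on an aromatic carbon. For the measured compounds named here, no measured step exchanges one group for another at this spot; the single recorded step moved a fluorine between two places on the same ring and was large, but it says nothing about what a methoxy does where the fluoro stood. The expectation for compound 3 in this assay is therefore uncertain, with a lean toward a somewhat higher number. Compound 3 is expected to give around 15 nM, in a range from 3 nM to 80 nM. That estimate corresponds to an expected 3.4-fold higher number from compound 2 to compound 3 (0.53 log units; beyond the scatter).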

Compound 3, half-maximal inhibitory concentration: 2430 nM
For compound 3 the middle estimate is 160-fold (2.21 log units) below the measured one; the whole stated range lies below it.
By their numbers in this assay, from the lowest: compound 2; then compound 1; then compound 3.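

On this assay the change from 4-fluorophenyl to 4-methoxyphenyl gives a 550-fold higher number from compound 2 to compound 3 (2.74 log units; beyond the scatter) and so weakens inhibition sharply, which shows that this spot responds strongly to which group stands on it, and not only to where a fluorine sits on the ring. Compared with the 3-fluorophenyl compound, the 4-methoxyphenyl compound shows a 50-fold higher number from compound 1 to compound 3 (1.70 log units; beyond the scatter) and is thus clearly the weakest of the three inhibitors here. Nothing available explains why this change costs so much.

Still open, on these data alone, is whether a methyl group, a chlorine or a hydroxy group on this carbon would keep the low number of compound 2 or fall toward that of compound 3. Also open, as far as these compounds go, is how a 3-methoxyphenyl group would compare with the 3-fluorophenyl group of compound 1.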